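From Propyl to Isopropyl on a Sulfur

A few compounds are considered here, and "the series" means these few. Any claim that something is new, unique, unknown or untested is made for them only; others in the source may bear on it.

In a functional assay on HepG2 cells (Homo sapiens) for cytotoxicity, read by MTT assay, with a stated time of 72 h (on this read-out lower numbers stand for stronger inhibition and higher numbers for weaker inhibition), compound 2 `CCC[S+]([O-])CCCCN=C=S` gives 3910 nM and compound 3 `CCCC[S+]([O-])CCCCN=C=S` gives 5930 nM, two values within the scatter of each other. Compound 1 `S=C=NCCCCSCc1ccccc1` gives 12600 nM, a higher number than either, which leaves compound 2 clearly apart from it.

Compound 4 `CC(C)[S+]([O-])CCCCN=C=S` has not yet been measured. It differs from compound 2 in one place: isopropyl in place of propyl on a sulfur. In words, it has isopropyl in place of propyl on a sulfur, with the same atoms joined differently.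

Among the measured compounds shown here, the one measured step that alters the group on this sulfur is a 1.5-fold higher number from compound 2 to compound 3 (0.18 log units; within the scatter). For the measured compounds named here, the data hold no branched example, so that small step is the only guide available. No change beyond the scatter is therefore expected in this assay, and no firm direction can be assigned. The expected step is a 1.2-fold higher number from compound 2 to compound 4 (0.06 log units; within the scatter). Compound 4 is estimated at 4500 nM, with an expected range from 2300 nM to 9000 nM.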

Compound 4, half-maximal inhibitory concentration: 2050 nM
Compound 4: middle estimate off by 2.2-fold (0.34 log units), on the high side; the whole stated range lies above it.
By their numbers in this assay, from the lowest: compounds 4, 2 and 3 (each within the scatter of the next, the first and the last beyond it); then compound 1.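

Among the compounds shown here, compound 4 is the first branched group on this sulfur, and in this assay swapping propyl for isopropyl, with the same atoms joined differently, gives a 1.9-fold lower number from compound 2 to compound 4 (0.28 log units; within the scatter) and so adds no clear change. Against the butyl of compound 3, however, isopropyl gives a 2.9-fold lower number from compound 3 to compound 4 (0.46 log units; beyond the scatter) and thus provides the first step on this sulfur that lies beyond the scatter, although a modest one. No measurement in hand accounts for either step.

The compounds shown leave open whether a tert-butyl group on this sulfur would extend the step seen with isopropyl. They also do not show how a cyclopropyl ring or a chain ending in an amine would behave at the same place.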